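The compounds below may be only part of what the source reports. "The series", "measured", "known", "first", "only" and "open" are said of these compounds alone.

Measured compounds in hand:
- compound 1 `O=C1c2c[n+]([O-])c3ccccc3c2C(=O)c2c1c1ccccc1n2Cc1cn([C@@H]2C[C@H](O)[C@@H](CO)O2)nn1`: 120 nM
- compound 2 `O=C1c2c[n+]([O-])c3ccccc3c2C(=O)c2c1c1ccccc1n2CCN1CCCC1`: 410 nM
- compound 3 `O=C1c2c[n+]([O-])c3ccccc3c2C(=O)c2c1c1ccccc1n2Cc1cn([C@H]2C[C@H](O)[C@@H](CO)O2)nn1`: 350 nM

In a functional assay on A549 cells (Homo sapiens) for cytotoxicity, read by MTT assay, with a stated time of 72 h (a lower number here means a stronger inhibitor, a higher number a weaker inhibitor), compound 2 stands at the highest of the three numbers. Its gap to compound 3 lies within the usual scatter, so nothing can be read into the order of those two; only compound 1 sits clearly apart, beyond the scatter, on the stronger side. Among the compounds with values here, the single one-change step within the set runs a 2.9-fold higher number from compound 1 to compound 3 (0.46 log units; beyond the scatter), a modest shift that rests on the fact that compounds 1 and 3 differ only in the configuration as drawn alone and concerns the sugar-bearing side chain, not the amine side chain carried by compound 2.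

Compound 4 `CN1CCN(CCCCCn2c3c(c4ccccc42)C(=O)c2c[n+]([O-])c4ccccc4c2C3=O)CC1` is not yet measured. It differs from compound 2 by 3-(4-methylpiperazin-1-yl)propyl in place of pyrrolidin-1-yl on a saturated chain carbon, two bonds along the chain from an aromatic nitrogen. Within the data shown here, no measured step touches this part of the series: the only step on record concerns a configuration change elsewhere, and compound 2 is the sole compound with a basic amine side chain. There is therefore no basis for expecting a shift beyond the scatter in either direction, and the expectation for compound 4 is set near compound 2 with a wide range. The estimated step is a 1.0-fold lower number from compound 2 to compound 4 (0.01 log units; within the scatter). Compound 4 is expected to give 400 nM, within a range of 150 nM to 1100 nM.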

Compound 4, half-maximal inhibitory concentration: 870 nM
Beside the measured number, compound 4's estimate is 2.2-fold (0.34 log units) below it; the measured number falls inside the stated range.
By their numbers in this assay, from the lowest: compound 1; then compounds 3 and 2 (each within the scatter of the next); then compound 4.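

In this assay, the saturated chain carbon two bonds along the chain from an aromatic nitrogen proves responsive to substitution, as pyrrolidin-1-yl giving way to 3-(4-methylpiperazin-1-yl)propyl produces a 2.1-fold higher number from compound 2 to compound 4 (0.33 log units; beyond the scatter). Within the data shown here, this is the first step on record for the amine side chain, and it is a modest one toward weaker inhibition, with the longer side chain ending in a methylpiperazine giving the highest number of the four compounds. Nothing measured bears on why this step occurs, as the only supporting observation concerns the configuration of the sugar-bearing side chain.

The step from 2-(pyrrolidin-1-yl)ethyl to 5-(4-methylpiperazin-1-yl)pentyl alters chain length and ring together, so the compounds shown leave open which of the two accounts for the shift; a 5-(pyrrolidin-1-yl)pentyl or a 2-(4-methylpiperazin-1-yl)ethyl side chain would separate them. Also open, from the compounds shown here alone, is how a morpholine ring or a plain alkyl chain with no amine at its end would read in this assay against compound 2.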